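Methyl in place of hydrogen on two amide side chains

This account rests on a few compounds, and the source may have more. Where it says the series, first, only, none or still open, it means among the compounds named here.

Compound 1 `C=C(c1ccc(OC)cc1NC(=O)CNC)c1ccc(OC)c2c1C=CC(C)(C)O2` and compound 2 `C=C(c1ccc(OC)cc1NC(=O)CNCC)c1ccc(OC)c2c1C=CC(C)(C)O2` share one core and differ only in the amide side chain; compound 3 `C=C(c1cc(OC)c(OC)c(OC)c1)c1ccc(OC)c(O)c1NC(=O)COC` and compound 4 `C=C(c1cc(OC)c(OC)c(OC)c1)c1ccc(OC)c(O)c1NC(=O)COCC` share a second core, and the difference between the two cores is not broken down here. The measured compounds were run in a functional assay on A2780 cells (Homo sapiens) for antiproliferative activity, read by MTT assay, with a stated time of 48 h; on this read-out higher numbers stand for weaker inhibition and lower numbers for stronger inhibition. Compound 1 gives 720 nM and compound 2 gives 2010 nM. Going by the values given here, the one step measured within a single core is a 2.8-fold higher number from compound 1 to compound 2 (0.45 log units; beyond the scatter); the change behind it is methyl in place of hydrogen on a saturated chain carbon bound to an amine nitrogen. Compound 3 gives 450 nM in this assay; its gap to compound 1 is within the scatter, while its gap to compound 2 lies beyond it.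

Among the compounds with values here, compound 4 carries the same kind of change as the one made from compound 1 to compound 2, namely (methyl in place of hydrogen on a saturated chain carbon bound to an oxygen on a saturated carbon). The place is not the same word for word: in the first pair the carbon is bound to an amine nitrogen, whereas in compound 4 it is bound to an oxygen on a saturated carbon, so the earlier step is a guide of the same kind rather than the same step. Because a 2.8-fold higher number from compound 1 to compound 2 (0.45 log units; beyond the scatter) points to weaker inhibition, the expected direction for compound 4 is a higher number than the value of compound 3, 450 nM. Compound 4 is expected to come in at 900 nM in this assay, a step of a 2.0-fold higher number from compound 3 to compound 4 (0.30 log units; within the scatter) from the value of compound 3. The range for compound 4 is expected to run from 400 nM to 2200 nM, allowing that the step in the new place may be smaller or absent.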

Compound 4, half-maximal inhibitory concentration: 1230 nM
Estimate against measurement, compound 4: 1.4-fold (0.14 log units) below, within the range that was stated.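

In this assay, methyl in place of hydrogen on a saturated chain carbon bound to an oxygen on a saturated carbon gives a 2.7-fold higher number from compound 3 to compound 4 (0.44 log units; beyond the scatter), so the lengthening of methoxymethyl to ethoxymethyl on the core of compound 3 goes with weaker inhibition. Set beside the step on the core of compound 1, where the carbon is bound to an amine nitrogen instead, the size of the change carries over from one core to the other: the same change on two cores in this assay, a 2.8-fold higher number (0.45 log units; beyond the scatter) from compound 1 to compound 2 and a 2.7-fold higher number (0.44 log units; beyond the scatter) from compound 3 to compound 4, 1.0-fold (0.01 log units) apart, within the scatter of two such steps. This agreement rests on just two pairs in a single assay, and since the core and the atom bound to the changed carbon differ together between the pairs, it neither separates their contributions nor shows that the step would hold on any further core or explain why it occurs.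

The compounds shown leave open whether the trend continues with a longer chain such as propoxy or propylamino, or with a branched chain such as isopropoxy. They also leave open whether the step keeps its size when the methoxymethyl side chain sits on the core of compound 1 or the amine side chain on the core of compound 3.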